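Amide series: expected cytotoxicity of compound 4

A few compounds are considered here, and "the series" means these few. Any claim that something is new, unique, unknown or untested is made for them only; others in the source may bear on it.

Values in an ADME assay on RAW264.7 cells (Mus musculus) for cytotoxicity, read by WST assay; on this read-out higher numbers stand for lower toxicity in this test and lower numbers for higher toxicity in this test:
Compound 1 `O=C(c1ccc(CN2C(=O)c3ccccc3S2(=O)=O)cc1)N1CCCCC1`: 69200 nM
Compound 2 `O=C(NCc1ccco1)c1ccc(CN2C(=O)c3ccccc3S2(=O)=O)cc1`: a limit of the test, > 100000 nM
Compound 3 `NC(=O)c1ccc(CN2C(=O)c3ccccc3S2(=O)=O)cc1`: a limit of the test, > 100000 nM

Compound 3 sits at the limit of > 100000 nM in this assay, at which 2 of the 3 values shown sit, so only a limit is known for it. Compound 4 `CN(Cc1ccco1)C(=O)c1ccc(CN2C(=O)c3ccccc3S2(=O)=O)cc1` differs from compound 3 by ((furan-2-yl)methyl)(methyl)amino in place of amino on a carbonyl carbon. Among the compounds with values here, the nearest measured steps are an at least 1.4-fold higher number from compound 1 to compound 3 (0.15 log units; that floor lies within the scatter) and a step that the two limits leave unreadable from compound 2 to compound 3; neither gives a readable size, and compound 1 is the only numbered value in this assay. The step of a number no higher from compound 3 to compound 4 (the limit leaves the size open) is therefore expected to be none beyond the scatter. Compound 4 is estimated at 100000 nM in this assay, with a range from 50000 nM to 200000 nM, most likely reported again as a limit.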

Compound 4, concentration lethal to 50% of the cells: > 100000 nM
Compound 4 ended at the assay's limit; the forecaster's own chance of this, stated with the estimate: 60%; the middle value sits exactly at the limit.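

In this assay compound 4 gives > 100000 nM, which is a limit of the test. A compound without the amide hydrogen, carrying ((furan-2-yl)methyl)(methyl)amino on the carbonyl carbon, can therefore also sit at this limit, and the change from piperidin-1-yl gives an at least 1.4-fold higher number from compound 1 to compound 4 (0.15 log units; that floor lies within the scatter). The steps from compound 2 and compound 3 to compound 4 cannot be read, and the series now sits largely at one ceiling: the limit of > 100000 nM in this assay, at which 3 of the 4 values shown sit.

From the compounds shown here alone, how compound 2, compound 3 and compound 4 rank beyond that limit stays open. Going by these compounds, it is also open whether a morpholin-4-yl group on the carbonyl carbon, or a longer chain in place of methyl, would give a numbered value.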